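Benzyl ester to free acid at the glycinamide-linked ester

The source may report more compounds than this note shows. Statements on the series, on what has been measured and on what is new or still open speak of the compounds shown alone.

Three compounds of the series carry a shared core and differ at the saturated chain carbon bound to an amide-type nitrogen and a carbonyl carbon. Compound 1 `CC[C@H](C)[C@H](NC(=O)CN(c1nc(Cl)nc2[nH]cnc12)C1CC1)C(=O)OCc1ccccc1` in a functional assay on the whole organism (Tail, strain ICR) with Mus musculus as the target, in the tail flick test, with a stated time of 60 min, at a dose of 25 umol/kg by the oral route (a higher number here means a stronger effect of the compound at the dose given, a lower number a weaker effect), gives 40.6%. Compound 2 `CC(C)C[C@H](NC(=O)CN(c1nc(Cl)nc2[nH]cnc12)C1CC1)C(=O)OCc1ccccc1` gives 27.3% in this assay, and compound 3 `O=C(CN(c1nc(Cl)nc2[nH]cnc12)C1CC1)N[C@@H](CCC(=O)OCc1ccccc1)C(=O)OCc1ccccc1` gives 53.7%. Compound 1 stands second highest of the three: the step of a number 13.1 percentage points higher from compound 1 to compound 3 (beyond the scatter) and the step of a number 13.3 percentage points lower from compound 1 to compound 2 (beyond the scatter) both lie beyond the scatter, as does a number 26.4 percentage points higher from compound 2 to compound 3 (beyond the scatter).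

Compound 4 `CC[C@H](C)[C@H](NC(=O)CN(c1nc(Cl)nc2[nH]cnc12)C1CC1)C(=O)O` differs from compound 1 in one place: hydrogen in place of benzyl on an oxygen next to a carbonyl group. Among the compounds with values here, none of the measured steps touches this oxygen; all three alter the side chain on the saturated chain carbon and leave the benzyl ester in place, so no step in the data bears directly on the change from compound 1 to compound 4. The expectation for compound 4 is therefore anchored only on compound 1 at 40.6%, with a wide range. Compound 4 is estimated at 34% in this assay, between 12% and 58%. This estimate means an expected step of a number 6.6 percentage points lower from compound 1 to compound 4 (within the scatter), a size that could fall within the scatter.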

Compound 4, a percentage reported as activity, at one dose (the size of the read-out at that dose, not a potency): 36%
Compound 4: the middle estimate sits 2 percentage points below what was measured; low and high end bracket the measured number.
By their numbers in this assay, from the lowest: compounds 2, 4 and 1 (each within the scatter of the next, the first and the last beyond it); then compound 3.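

In this assay, hydrogen in place of benzyl on the oxygen next to a carbonyl group, which reads as benzyloxycarbonyl to carboxy, gives a number 4.6 percentage points lower from compound 1 to compound 4 (within the scatter); with the sec-butyl side chain, the benzyl group is therefore not required for a read-out of this size at this one dose. Within the data shown here, this is the first change at the ester oxygen, and it contrasts with the side-chain changes made with the benzyl ester in place, which gave a number 13.3 percentage points lower from compound 1 to compound 2 (beyond the scatter) and a number 13.1 percentage points higher from compound 1 to compound 3 (beyond the scatter), so in this small set the side-chain changes move the number beyond the scatter while this single ester change does not. The data on hand offer no explanation for this result.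

From the compounds shown here alone, whether hydrogen in place of benzyl is equally tolerated with the isobutyl of compound 2 or the 2-(benzyloxycarbonyl)ethyl of compound 3 remains open, as a single pair cannot show this. Also open, going by these compounds, is how a methyl ester or a primary amide at this carbonyl would read, and whether either would stay within the scatter of compound 1 and compound 4.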